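This account rests on a few compounds, and the source may have more. Where it says the series, first, only, none or still open, it means among the compounds named here.

Working notes on the series. Compound 1 `CN(CCN(C)C(=O)n1cccn1)Cc1cccc(OCc2ccccc2)c1` and compound 2 `CN(CCN(C)C(=O)n1cc(C#N)cn1)Cc1cccc(OCc2ccccc2)c1` share one core; compound 3 `O=C(N1CCN(C(c2ccc(OCc3ccccc3)cc2)c2ccc(OCc3ccccc3)cc2)CC1)n1cccn1` and the not yet measured compound 4 `N#Cc1cnn(C(=O)N2CCN(C(c3ccc(OCc4ccccc4)cc3)c3ccc(OCc4ccccc4)cc3)CC2)c1` share another. The difference between the two cores is not broken down here.

In an assay on membranes from brain for binding affinity to Fatty-acid amide hydrolase 1 (Mus musculus), read by fluorescence, with stated times of 1 h and 30 min (on this read-out higher numbers stand for weaker inhibition and lower numbers for stronger inhibition), compound 1 gives 3000 nM. In this assay compound 2 gives 190 nM. The change between the two is cyano in place of hydrogen on an aromatic carbon, and it produced a 16-fold lower number from compound 1 to compound 2 (1.20 log units; beyond the scatter).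

For compound 3 only a limit is reported in this assay, namely > 100000 nM. Where compound 3 stands among the measured compounds rests on (the limit of > 100000 nM in this assay, at which 1 of the 3 values shown sits).

Compound 4 carries the same change relative to compound 3, (cyano in place of hydrogen on an aromatic carbon). The place of the change is the same in both pairs, so it counts as the same change on a different core. Within the data shown here, the one measured instance starts from a core that already gives a number, whereas the starting point for compound 4 is known only as a limit, so even a step of the same size may not bring compound 4 down to a reportable number.

The step expected from compound 3 to compound 4 in this assay is an at least 2.5-fold lower number from compound 3 to compound 4 (0.39 log units; beyond the scatter). That expectation rests on a 16-fold lower number from compound 1 to compound 2 (1.20 log units; beyond the scatter) and, for the starting point, on (the limit of > 100000 nM in this assay, at which 1 of the 3 values shown sits). The estimate for compound 4 in this assay is 40000 nM, with a range from 6000 nM to 300000 nM, and a real chance that only a limit is reported again.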

Compound 4, half-maximal inhibitory concentration: 790000 nM
Compound 4: middle estimate off by 20-fold (1.30 log units), on the low side; the measured number lies above the stated range.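

No step from compound 3 to compound 4 can be read in this assay, because the value of compound 3 is only a limit: the limit of > 100000 nM in this assay, at which 1 of the 4 values shown sits.

The compounds shown leave open how far cyano in place of hydrogen on an aromatic carbon moves the number on the core of compound 3, and so whether the step seen on the core of compound 1 carries over to that core.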